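Removing a trifluoromethyl from a sulfonyl anilide

A few compounds are considered here, and "the series" means these few. Any claim that something is new, unique, unknown or untested is made for them only; others in the source may bear on it.

Measured compounds:
Compound 1, `O=C(Nc1cc(C(F)(F)F)ccc1C(F)(F)F)c1ccc(Sc2ccc(O)cc2)cc1`: 11400 nM
Compound 2, `O=C(Nc1cc(C(F)(F)F)ccc1C(F)(F)F)c1ccc(S(=O)(=O)c2ccc(O)cc2)cc1`: 23200 nM

In a functional assay on LNCaP cells (Homo sapiens) for antiproliferative activity, read by fluorescence and propidium iodide staining, with a stated time of 96 h (a lower number here means a stronger inhibitor, a higher number a weaker inhibitor), compound 2 gives 23200 nM, the higher of the two numbers recorded. Among the compounds with values here, its nearest neighbour is compound 1, which in this assay gives 11400 nM; the single change between them, a (4-hydroxyphenyl)sulfonyl in place of a (4-hydroxyphenyl)sulfanyl, brought a 2.0-fold higher number from compound 1 to compound 2 (0.31 log units; beyond the scatter).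

Compound 3, `O=C(Nc1ccccc1C(F)(F)F)c1ccc(S(=O)(=O)c2ccc(O)cc2)cc1`, differs from compound 2 in one place: hydrogen in place of trifluoromethyl on an aromatic carbon. Within the data shown here, no measured step touches this part of the shared core, so the only step at hand, a 2.0-fold higher number from compound 1 to compound 2 (0.31 log units; beyond the scatter), concerns a different position and gives no direct guide. The expectation for compound 3 therefore rests on the number for compound 2 alone, with a wide margin on both sides, and the expected step of a 1.3-fold higher number from compound 2 to compound 3 (0.11 log units; within the scatter) is not clearly beyond the scatter. On that basis compound 3 is estimated at 30000 nM, within a range of 10000 nM to 90000 nM.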

Compound 3, half-maximal inhibitory concentration: 39300 nM
Estimate against measurement, compound 3: 1.3-fold (0.12 log units) below, within the range that was stated.
By their numbers in this assay, from the lowest: compound 1; then compounds 2 and 3 (each within the scatter of the next).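

In this assay, replacing this trifluoromethyl with hydrogen gives a 1.7-fold higher number from compound 2 to compound 3 (0.23 log units; within the scatter), so compound 2 and compound 3 cannot be told apart in this test. Within the data shown here, this is the first look at this position, and it shows that four heavy atoms can leave this aromatic carbon, while the other trifluoromethyl group stays in place, without a step beyond the usual scatter. No evidence is at hand to explain this result.

As far as these compounds go, it remains open whether a larger or different group on this carbon, such as an amine, a carboxylic acid or a longer alkyl chain, would shift the number beyond the scatter. Also open, from the compounds shown here alone, is whether removing the remaining trifluoromethyl group would have any clearer effect than the step seen here.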